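From 4-Chlorophenyl to 2-Methoxyphenyl on a Shared Core

This account rests on a few compounds, and the source may have more. Where it says the series, first, only, none or still open, it means among the compounds named here.

Of the compounds shown here, two have been measured in a functional assay on UACC-62 cells (Homo sapiens) for inhibition, read by sulforhodamine B assay, with a stated time of 48 h, tested at 10 uM; a lower number here means less inhibition, a higher number more inhibition at the concentration tested (going by the name of the read-out). Compound 1 `c1cn2cc(-c3ccsc3)nc(-c3ccc4ncn(C5CCCCC5)c4c3)c2n1` gives 18.4%, and compound 2 `Clc1ccc(-c2cn3ccnc3c(-c3ccc4ncn(C5CCCCC5)c4c3)n2)cc1` gives 30.5%. For the measured compounds named here, compound 2 thus stands highest of the two numbers, with compound 1 as its only neighbour, separated by a number 12.1 percentage points higher from compound 1 to compound 2 (beyond the scatter). Compound 3 `COc1ccccc1-c1cn2ccnc2c(-c2ccc3ncn(C4CCCCC4)c3c2)n1` has not yet been measured; it differs from compound 2 by 2-methoxyphenyl in place of 4-chlorophenyl on an aromatic carbon. Going by the values given here, the single measured step, thiophen-3-yl to 4-chlorophenyl, moved the read-out by a modest amount beyond the scatter, but it does not involve 2-methoxyphenyl and so gives no direct guide to the present change. Among the compounds with values here, with one six-membered aromatic ring of carbon only replaced by another and no comparable step to draw on, the expected movement in this assay is a number 4.5 percentage points lower from compound 2 to compound 3 (within the scatter), a step within the scatter. Compound 3 is therefore estimated at 26%, with a range from 10% to 42%.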

Compound 3, a percentage reported as inhibition, at one concentration (the size of the read-out at that concentration, not a potency): 25.1%
For compound 3 the middle estimate is 0.9 percentage points above the measured one; low and high end bracket the measured number.
By their numbers in this assay, from the lowest: compounds 1, 3 and 2 (each within the scatter of the next, the first and the last beyond it).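

In this assay the replacement of 4-chlorophenyl by 2-methoxyphenyl at this position, which brings in an oxygen and a hydrogen-bond acceptor, gives a number 5.4 percentage points lower from compound 2 to compound 3 (within the scatter), so this change cannot be told apart from repeat measurement. The replacement of thiophen-3-yl by 2-methoxyphenyl gives a number 6.7 percentage points higher from compound 1 to compound 3 (within the scatter), which leaves compound 3 unresolved from both neighbours even though those two are separated by a number 12.1 percentage points higher from compound 1 to compound 2 (beyond the scatter). Nothing measured here offers an explanation for these readings.

In the step to compound 3, the substituent and its place on the phenyl ring change together, so 4-methoxyphenyl or 2-chlorophenyl at this position would be needed to separate the two. Going by these compounds, how an aminomethyl group or a carboxylic acid on that phenyl ring would read also remains open.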